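Oxanylaminomethyl replacing isopropylamino on the aryl ring

The source may hold more compounds than are shown below. What is called first, only, known or untested is meant among the compounds shown, and "the series" means these compounds.

Compound 2 `CC(C)Nc1ccc(-c2ccn3c(CC4CC4)nnc3c2C(F)(F)F)cc1Cl` gives 3.4 nM in an assay on cells for binding affinity to metabotropic glutamate receptor 2 (Homo sapiens), read by scintillation proximity assay; a higher number here means weaker binding, a lower number tighter binding. It stands second highest of the three numbers recorded: compound 1 `CC(C)Nc1ccc(-c2ccn3c(CC4CC4)nnc3c2C(F)(F)F)cc1F` gives 2.2 nM, and the step of a 1.5-fold higher number from compound 1 to compound 2 (0.19 log units; within the scatter) is within the scatter, so the two cannot be ordered. Among the compounds with values here, compound 3 `Clc1cc(-c2ccn3c(CC4CC4)nnc3c2Cl)ccc1NC1CCOCC1` gives 19.5 nM, a weaker figure that lies beyond the scatter from compound 2; compound 3 differs from compound 2 in more than one place, so no single step is drawn between them.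

Compound 4 `FC(F)(F)c1c(-c2ccc(CNC3CCOCC3)c(Cl)c2)ccn2c(CC3CC3)nnc12` is the next member. Relative to compound 2 the change is ((oxan-4-yl)amino)methyl in place of isopropylamino on an aromatic carbon. Within the data shown here, no measured step bears directly on this change: the only step recorded, from compound 1 to compound 2, concerns a halogen swap and is within the scatter. Among the measured compounds shown here, compound 3, the only measured compound carrying an oxan-4-yl amine, shows the weakest number of the three, but its core also differs from that of compound 2, so its value is only a loose pointer.

The expectation for this assay is a moderate move toward weaker binding, a 3.5-fold higher number from compound 2 to compound 4 (0.55 log units; beyond the scatter), with wide uncertainty. Compound 4 is estimated at 12 nM, expected to fall between 4 nM and 40 nM.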

Compound 4, dissociation constant: 54 nM
Beside the measured number, compound 4's estimate is 4.5-fold (0.65 log units) below it; the whole stated range lies below it.
By their numbers in this assay, from the lowest: compounds 1 and 2 (each within the scatter of the next); then compound 3; then compound 4.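

In this assay, this position, on an aromatic carbon ortho to a chloro group, does not tolerate every amine-bearing group equally: replacing isopropylamino with ((oxan-4-yl)amino)methyl gives a 16-fold higher number from compound 2 to compound 4 (1.20 log units; beyond the scatter). Within the data shown here, of the two single-place steps available, only this one lies beyond the scatter, whereas the halogen swap, a 1.5-fold higher number from compound 1 to compound 2 (0.19 log units; within the scatter), lies within it, so this is the first direct sign that the binding number responds to the group at this position. No measurement in hand gives a reason for the size of this step.

The entering group differs from isopropylamino in more than one feature, as it brings a methylene link, a six-membered non-aromatic ring and a ring oxygen together, and the compounds shown do not separate their contributions. On the core of compound 2, an (isopropylamino)methyl group would isolate the methylene link, while a (cyclohexylamino)methyl group would test the ring without its oxygen.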